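Ethylsulfanyl analogue of compound 3: expected paw-edema inhibition

The source may hold more compounds than are shown below. What is called first, only, known or untested is meant among the compounds shown, and "the series" means these compounds.

Measured in a functional assay on the whole organism (strain Sprague-Dawley) with Rattus norvegicus as the target, read by paw edema, with a stated time of 5 h, at a dose of 50 mg/kg by the oral route; a lower number here means less inhibition, a higher number more inhibition at the dose given (going by the name of the read-out):
compound 1 `CCSc1ncc(-c2ccc(S(C)(=O)=O)cc2)n1-c1ccc(F)cc1` gives 43%
compound 2 `CCSc1ncc(-c2ccc(S(C)(=O)=O)cc2)n1-c1ccc(Cl)cc1` gives 52.7%
compound 3 `CSc1ncc(-c2ccc(S(C)(=O)=O)cc2)n1-c1ccc(Br)cc1` gives 88%

Compound 3 stands highest of the three numbers, beyond the scatter from compound 2 and from compound 1. Among the measured compounds shown here, the only single-point step measured, a number 9.7 percentage points higher from compound 1 to compound 2 (within the scatter), lies within the scatter and concerns the halogen, not the sulfanyl chain. Compound 4 `CCSc1ncc(-c2ccc(S(C)(=O)=O)cc2)n1-c1ccc(Br)cc1` is unmeasured; it differs from compound 3 by methyl in place of hydrogen on a saturated chain carbon bound to a sulfur. For the measured compounds named here, no measured pair isolates this change: compound 1 and compound 2 carry the ethylsulfanyl group, but each also carries a different halogen, so their lower values cannot be set against compound 3 for the chain alone. Going by the values given here, with no bearing step, the expectation is no step beyond the scatter, a number 10 percentage points lower from compound 3 to compound 4 (within the scatter), though the range is kept wide. Compound 4 is expected at 78%, between 50% and 95%.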

Compound 4, a percentage reported as inhibition, in the whole organism at one dose (the size of the read-out at that dose, not a potency): 59%
Beside the measured number, compound 4's estimate is 19 percentage points above it, and the stated range covers the measured number.
By their numbers in this assay, from the lowest: compounds 1, 2 and 4 (each within the scatter of the next, the first and the last beyond it); then compound 3.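

In this assay, the sulfanyl chain now has its first isolated reading, and lengthening methylsulfanyl to ethylsulfanyl with bromo held fixed gives a number 29 percentage points lower from compound 3 to compound 4 (beyond the scatter). With ethylsulfanyl held fixed, the halogen gives a number 6.3 percentage points higher from compound 2 to compound 4 (within the scatter) and a number 16 percentage points higher from compound 1 to compound 4 (beyond the scatter), so only the bromo and fluoro pair separates beyond the scatter. No available measurement explains these steps.

On these data alone, whether the chain step carries over to the chloro and fluoro compounds remains open. So does the reading of a longer chain such as propylsulfanyl in this assay.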